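Lengthening the amine arm: compound 2 to compound 4

The source may hold more compounds than are shown below. What is called first, only, known or untested is meant among the compounds shown, and "the series" means these compounds.

Measured compounds in a physicochemical assay for lipophilicity, using the shake flask method, measured as octanol-water partition, at pH 7.4; on this read-out higher numbers stand for higher lipophilicity and lower numbers for lower lipophilicity:
- compound 1, `COc1cc(/C=C/C(=O)Nc2ccccc2)ccc1OCCCN(C)C`: 1.55
- compound 2, `COc1cc(/C=C/C(=O)Nc2ccccc2)ccc1OCCCN1CCCCC1`: 1.58
- compound 3, `COc1cc(/C=C/C(=O)Nc2ccccc2)ccc1OCCCCN(C)C`: 1.57

Compound 2 stands together with compounds 1 and 3; the gaps to both, a number 0.03 log units higher from compound 1 to compound 2 (within the scatter) and a number 0.01 log units lower from compound 2 to compound 3 (within the scatter), lie within the scatter, so the three cannot be told apart on this read-out.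

Compound 4, `CCN(CC)CCCCOc1ccc(/C=C/C(=O)Nc2ccccc2)cc1OC`, has not yet been measured. Relative to compound 2 the change is (diethylamino)methyl in place of piperidin-1-yl on a saturated chain carbon, three bonds along the chain from an oxygen on an aromatic ring.

Two measured steps resemble it. Replacing the ring with an open chain, a number 0.01 log units lower from compound 2 to compound 3 (within the scatter), changed nothing beyond the scatter. Adding one more chain carbon to the amine arm, a number 0.02 log units higher from compound 1 to compound 3 (within the scatter), likewise stayed within the scatter. Compound 4 combines an open chain with a longer arm, so no step beyond the scatter is expected in this assay, perhaps a slight rise: the expected step is a number 0.07 log units higher from compound 2 to compound 4 (within the scatter).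

For compound 4 the estimate in this assay is therefore 1.65, with a range from 1.35 to 1.95.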

Compound 4, partition coefficient: 1.59
Compound 4: the middle estimate sits 0.06 log units above what was measured; the range from low to high includes it.
By their numbers in this assay, from the lowest: compounds 1, 3, 2 and 4 (each within the scatter of the next).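

In this assay the new compound adds three comparisons: a number 0.01 log units higher from compound 2 to compound 4 (within the scatter) and a number 0.02 log units higher from compound 3 to compound 4 (within the scatter) and a number 0.04 log units higher from compound 1 to compound 4 (within the scatter). This shows that opening the piperidin-1-yl ring into (diethylamino)methyl, with the same heavy atoms by count, leaves the read-out within the scatter, and so does diethylamino in place of dimethylamino on the longer arm. Nothing available here accounts for this sameness.

Going by these compounds, all four compounds carry a tertiary amine at the end of the arm, so it remains open whether a primary amine or a carboxylic acid there would also stay within the scatter. On these data alone, a much longer chain between the oxygen and the amine remains equally open.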